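Piperidine tail and chain change: compound 2 to compound 3

A few compounds are considered here, and "the series" means these few. Any claim that something is new, unique, unknown or untested is made for them only; others in the source may bear on it.

In a functional assay for inhibition, read by fluorescence and spectrophotometry, with a stated time of 30 h (on this read-out lower numbers stand for stronger inhibition and higher numbers for weaker inhibition), compound 1 `COc1ccc(-c2cc(=O)c3ccc(OCCCN4CCC(C)CC4)cc3o2)cc1` gives 42600 nM and compound 2 `COc1ccc(-c2cc(=O)c3ccc(OCCCCCN4CCC(CCO)CC4)cc3o2)cc1` gives 49400 nM on the same read-out. For the measured compounds named here, these two numbers lie within the scatter of each other, so compound 2 stands level with the only other compound measured so far.

The change to the still unmeasured compound 3 `COc1ccc(-c2cc(=O)c3ccc(OCCCCCCN4CCC(C)CC4)cc3o2)cc1` reads (4-methylpiperidin-1-yl)methyl in place of 4-(2-hydroxyethyl)piperidin-1-yl on a saturated chain carbon, five bonds along the chain from an oxygen on an aromatic ring and leaves the shared core untouched. Compound 3 thus carries the 4-methylpiperidin-1-yl end of compound 1 on a chain that neither measured compound has.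

Going by the values given here, only one measured step bears on this change. No measurement separates the chain from the group at its end, and a shift beyond the scatter is not expected because a 1.2-fold higher number from compound 1 to compound 2 (0.06 log units; within the scatter) alters both and stays within the scatter. The expected step in this assay is a 1.2-fold lower number from compound 2 to compound 3 (0.07 log units; within the scatter) with no firm direction and nothing beyond the scatter. For compound 3 the estimated value is 42000 nM with an expected range from 16000 nM to 95000 nM in this assay.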

Compound 3, half-maximal inhibitory concentration: 57200 nM
Compound 3: the middle estimate sits 1.4-fold (0.13 log units) below what was measured; measured number inside the range.
By their numbers in this assay, from the lowest: compounds 1, 2 and 3 (each within the scatter of the next).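

In this assay, for the compounds shown here, the step of a 1.3-fold higher number from compound 1 to compound 3 (0.13 log units; within the scatter) is the first to keep the 4-methylpiperidin-1-yl end fixed while only the chain differs, and 3-(4-methylpiperidin-1-yl)propyl in place of 4-methylpiperidin-1-yl leaves the two compounds level. The step of a 1.2-fold higher number from compound 2 to compound 3 (0.06 log units; within the scatter) also leaves the two compounds level, although 4-(2-hydroxyethyl)piperidin-1-yl carries a hydrogen-bond donor and (4-methylpiperidin-1-yl)methyl carries none, so across these three compounds neither the chain nor the end group gives a difference beyond the scatter. Nothing on hand accounts for these numbers or says how the compounds act in this read-out.

Going by these compounds alone, still open is the effect of the end group alone, as compound 2 differs from compound 3 in both the chain and the substituent on the piperidine ring, and no pair here isolates the 2-hydroxyethyl group from the methyl group on one chain. Also open, as far as these compounds go, is whether a different end on the chain, such as a morpholin-4-yl group, a dimethylamino group or a carboxylic acid in place of the piperidine, would move the number beyond the scatter.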